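This account rests on a few compounds, and the source may have more. Where it says the series, first, only, none or still open, it means among the compounds named here.

Measured so far, in a functional assay on HT-29 cells (Homo sapiens) for cytotoxicity, read by sulforhodamine B assay; a higher number here means a weaker inhibitor of growth, a lower number a stronger inhibitor of growth:
- compound 1 `CC1=CC[C@@H]([C@@](C)(O)CCCC(C)(C)NC(=S)N/N=C\c2ccccc2)CC1`: 9960 nM
- compound 2 `CC1=CC[C@@H]([C@@](C)(O)CCCC(C)(C)NC(=S)N/N=C\c2ccc(C)cc2)CC1`: 10400 nM
- compound 3 `CC1=CC[C@@H]([C@@](C)(O)CCCC(C)(C)NC(=S)N/N=C\c2ccc(N(C)C)cc2)CC1`: 27700 nM

Compound 3 gives the highest of the three numbers in this assay. Within the data shown here, the two steps leading to it, a 2.8-fold higher number from compound 1 to compound 3 (0.44 log units; beyond the scatter) and a 2.7-fold higher number from compound 2 to compound 3 (0.43 log units; beyond the scatter), are modest but beyond the scatter, whereas a 1.0-fold higher number from compound 1 to compound 2 (0.02 log units; within the scatter) stays within it, so the only change that has moved this assay so far is the arrival of dimethylamino on the aromatic carbon.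

Compound 4 `CC1=CC[C@@H]([C@@](C)(O)CCCC(C)(C)NC(=S)N/N=C\c2ccccc2[N+](=O)[O-])CC1` differs from compound 3 by 2-nitrophenyl in place of 4-(dimethylamino)phenyl on a carbon with a double bond to nitrogen. Among the measured compounds shown here, no measured step involves a nitro group, so that part of the change is uninformed. The other part, loss of dimethylamino, is informed by compounds 1 and 2: both steps to compound 3 raised the number, so reverting should bring the number back toward those of compound 1 and compound 2, with the nitro contribution left open. A modest fall is therefore expected for compound 4, an estimated step of a 2.3-fold lower number from compound 3 to compound 4 (0.36 log units; beyond the scatter). The estimate for compound 4 in this assay is 12000 nM, with a range of 4000 nM to 40000 nM.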

Compound 4, concentration for 50% growth inhibition: 6940 nM
Beside the measured number, compound 4's estimate is 1.7-fold (0.24 log units) above it; low and high end bracket the measured number.
By their numbers in this assay, from the lowest: compounds 4, 1 and 2 (each within the scatter of the next); then compound 3.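

In this assay a nitro group on the aromatic ring leaves the number where hydrogen and methyl put it: both a 1.4-fold lower number from compound 1 to compound 4 (0.16 log units; within the scatter) and a 1.5-fold lower number from compound 2 to compound 4 (0.18 log units; within the scatter) lie within the scatter. Among these compounds, the only new step beyond the scatter is a 4.0-fold lower number from compound 3 to compound 4 (0.60 log units; beyond the scatter), so compound 3 now stands apart from three compounds rather than two. Among the substituents shown on this ring, dimethylamino alone has moved the number, while compound 1, compound 2 and compound 4 cannot be ordered.

From the compounds shown here alone, how 4-nitrophenyl, or a ring carrying a primary amine or a carboxylic acid, would read remains open, so neither the place of the nitro group nor the role of the amine's methyl groups can be judged. No measurement at hand accounts for the separate position of dimethylamino.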